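From a ketone to a thioether in a cytotoxicity series

The source may report more compounds than this note shows. Statements on the series, on what has been measured and on what is new or still open speak of the compounds shown alone.

Among the compounds with values here, compound 3 `COc1ccc(-c2nc(CC(=O)c3cccc(Cl)c3)nc3ccsc23)cn1` carries a (3-chlorophenyl)carbonyl on a saturated chain carbon bound to an aromatic carbon; in an ADME assay on cells (Homo sapiens) for cytotoxicity, read by resazurin assay, with a stated time of 5 days (a lower number here means that less compound is tolerated, a higher number that more compound is tolerated), compound 3 gives 30000 nM, the only number among the three values in hand. Compound 1 `COc1ccc(-c2nc(CNc3cccc(Cl)c3)nc3ccsc23)cn1` reaches only a limit, > 50000 nM. Compound 2 `COc1ccc(-c2nc(C[S+]([O-])c3cccc(Cl)c3)nc3ccsc23)cn1` likewise stops at a limit, > 50000 nM. Compound 4 `COc1ccc(-c2nc(CSc3cccc(Cl)c3)nc3ccsc23)cn1` has not been measured; it differs from compound 3 as follows ((3-chlorophenyl)sulfanyl in place of (3-chlorophenyl)carbonyl on a saturated chain carbon bound to an aromatic carbon). Within the data shown here, two measured steps bear on this change, and both lead into the ketone: an at least 1.6-fold lower number from compound 1 to compound 3 (0.22 log units; that floor lies within the scatter) and an at least 1.6-fold lower number from compound 2 to compound 3 (0.22 log units; that floor lies within the scatter), with the stated floor of each lying within the scatter, while the limit of > 50000 nM in this assay, at which 2 of the 3 values shown sit, leaves their true size unknown. Compound 4 moves away from the ketone, so the step is expected to run the other way, with compound 4 returning toward that limit in this assay, which amounts to an expected 1.7-fold higher number from compound 3 to compound 4 (0.22 log units; within the scatter). Compound 4 is therefore estimated at 50000 nM, with a range from 25000 nM to 100000 nM.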

Compound 4, half-maximal cytotoxic concentration: > 10000 nM
Compound 4 ended at the assay's limit; the forecaster's own chance of this, stated with the estimate: 60%; the middle value does not contradict the limit.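

Compound 4 stops at a limit, > 10000 nM, so none of its steps from compound 1, compound 2 or compound 3 can be read. The compounds shown leave open whether the (3-chlorophenyl)sulfanyl of compound 4 and the (3-chlorophenyl)carbonyl of compound 3 differ at all in this assay.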